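The source may report more compounds than this note shows. Statements on the series, on what has been measured and on what is new or still open speak of the compounds shown alone.

Measured so far:
- compound 2, `COc1cc(C)cc(-c2nn(CC#N)cc2-c2ccnc(-c3ccc(N(C)C)cc3)c2)c1`, gives 99%
- compound 1, `COc1cc(C)cc(-c2c(-c3ccnc(-c4ccc(N(C)C)cc4)c3)cnn2CC#N)c1`, gives 62%

Both compounds were tested in a functional assay on HOP-62 cells (Homo sapiens) for cytotoxicity, read by sulforhodamine B assay, with a stated time of 48 h, tested at 0.01 uM (on this read-out higher numbers stand for a weaker effect at the one concentration tested and lower numbers for a stronger effect), so a high number means the cells were barely affected and a low number means they were hit hard. Among the two numbers shown, compound 2 stands highest with 99%, that is, almost no effect at the single concentration tested. For the measured compounds named here, its only neighbour, compound 1, gives 62%, a number well below that of compound 2 and beyond the usual scatter; the two structures differ in more than one place, so nothing can be said about which change accounts for this gap.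

The step now followed leads from compound 2 to compound 3, `Cc1cc(O)cc(-c2nn(CC#N)cc2-c2ccnc(-c3ccc(N(C)C)cc3)c2)c1`. The change is small: hydrogen in place of methyl on an oxygen on an aromatic ring. Going by the values given here, no measured pair shows what this particular change does, so the expectation rests on compound 2 alone. Because compound 2 already gives 99%, and the read-out cannot rise far above that, the expected step from compound 2 to compound 3 is a number 5 percentage points lower from compound 2 to compound 3 (within the scatter), no more than the scatter. For compound 3 the estimate is therefore 94%, with a range from 72% to 105%.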

Compound 3, a percentage reported as activity, at one concentration (the size of the read-out at that concentration, not a potency): 89%
Compound 3: the middle estimate sits 5 percentage points above what was measured; measured number inside the range.
By their numbers in this assay, from the lowest: compound 1; then compounds 3 and 2 (each within the scatter of the next).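

Going from 3-methoxy-5-methylphenyl to 3-hydroxy-5-methylphenyl, with hydrogen in place of methyl on an oxygen on an aromatic ring, is the first change in a single place among these compounds, and in this assay it reads as a number 10 percentage points lower from compound 2 to compound 3 (within the scatter). At this position, then, the methyl on the oxygen can be removed without a shift that this read-out can tell apart from the ordinary spread of repeat measurements, and the free hydroxy of compound 3 brings no clear gain in effect at this one concentration. Nothing available here offers an explanation for this result.

The compounds shown leave open whether a larger or different group at this place, such as an ethoxy group, an amine or a carboxylic acid, would move the reading beyond the scatter. They also leave open whether the same swap of methoxy to hydroxy would read the same way on compound 1, whose number in this assay leaves more room for a change to show in either direction.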